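Turning one ring stereocentre: compound 2 to compound 3

The source may hold more compounds than are shown below. What is called first, only, known or untested is meant among the compounds shown, and "the series" means these compounds.

Of the compounds shown here, two have so far been tested in an assay on HEK293 cells for antagonist activity at transient receptor potential cation channel subfamily V member 3 (Homo sapiens), read by FLIPR and calcium flux; on this read-out lower numbers stand for stronger inhibition and higher numbers for weaker inhibition. Compound 1 `OC(c1ncccn1)C1(c2ccc(OC(F)(F)F)cc2)CCC1` gives 1540 nM in this assay. Compound 2 `O[C@@]1(c2ccccn2)CC[C@@H](c2ccc(C(F)(F)F)cc2)C1` gives 240 nM in this assay, the lower of the two numbers, and its nearest neighbour, compound 1, sits a higher number away, a gap beyond the usual scatter. Compound 3 `O[C@]1(c2ccccn2)CC[C@@H](c2ccc(C(F)(F)F)cc2)C1` has not yet been measured in this assay. Between compound 2 and compound 3 (the two compounds have the same atoms and bonds and differ only in configuration as drawn: 1 of 2 stereo elements differ; a stereocentre at a saturated ring carbon is drawn S in compound 2 and R in compound 3). For the measured compounds named here, no pair of measured compounds shows what such a change of configuration does here, so the direction of the step is uncertain; a change that is more likely to cost than to gain potency is expected, with a wide margin either way. The step from compound 2 to compound 3 is therefore estimated at a 2.9-fold higher number from compound 2 to compound 3 (0.46 log units; beyond the scatter). Compound 3 is expected to give 700 nM in this assay, within a range from 150 nM to 3500 nM.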

Compound 3, antagonist equilibrium constant: 130 nM
The estimate for compound 3 lay 5.4-fold (0.73 log units) above the measured number, and the stated range ends above it.
By their numbers in this assay, from the lowest: compounds 3 and 2 (each within the scatter of the next); then compound 1.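

For the compounds shown here, this is the first pair in which a single feature can be read on its own. In this assay, turning this saturated ring carbon from S to R gives a 1.8-fold lower number from compound 2 to compound 3 (0.27 log units; within the scatter), so the two drawn configurations cannot be told apart on this read-out. This also means that, at this carbon and with everything else held as in these two compounds, the assay gives no sign that one arrangement is required, and the step can be assigned to this stereocentre alone because nothing else varies: the fact that compounds 2 and 3 differ only in the configuration as drawn.

On these data alone, whether that tolerance holds for the second stereocentre, or once the other groups on the shared core change, remains open. So does the question of how an amine or a carboxylic acid in place of the trifluoromethyl group would read in this assay.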